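Working notes: from compound 3 to compound 4

This account rests on a few compounds, and the source may have more. Where it says the series, first, only, none or still open, it means among the compounds named here.

- compound 1 `COc1ccc(CNc2ccc(NC(=O)c3cc(Cl)ccc3O)c(Cl)c2)cc1` gives 80700 nM
- compound 2 `O=C(Nc1ccc(NCc2cc(Cl)cc(Cl)c2)cc1Cl)c1cc(Cl)ccc1O` gives 13300 nM
- compound 3 `O=C(Nc1ccc(NCc2cccnc2Cl)cc1Cl)c1cc(Cl)ccc1O` gives 101000 nM

All three numbers come from an ADME assay on A549 cells (Homo sapiens) for cytotoxicity, read by resazurin assay, with a stated time of 48 h; on this read-out lower numbers stand for higher toxicity in this test and higher numbers for lower toxicity in this test. Compound 3 stands at the upper end of this small set, a level it shares with compound 1, and the step between them stays within the scatter: a 1.3-fold higher number from compound 1 to compound 3 (0.10 log units; within the scatter). Compound 2 alone sits lower: a 7.6-fold higher number from compound 2 to compound 3 (0.88 log units; beyond the scatter).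

The next structure is compound 4 `O=C(Nc1ccc(NCc2ccc(O)nc2)cc1Cl)c1cc(Cl)ccc1O`. The change is 6-hydroxypyridin-3-yl in place of 2-chloropyridin-3-yl on a saturated chain carbon bound to a nitrogen on an aromatic ring, with 6-hydroxypyridin-3-yl in place of 2-chloropyridin-3-yl on a saturated chain carbon bound to a nitrogen on an aromatic ring.

Among the measured compounds shown here, the measured steps at this same place are the only guide. Of the groups tried there, only 3,5-dichlorophenyl moved the number beyond the scatter, and that was a modest step: a 6.1-fold lower number from compound 1 to compound 2 (0.78 log units; beyond the scatter). Compound 4 lacks this group, so it more closely resembles compound 1 and compound 3, although three compounds make a thin basis. For the measured compounds named here, no measured compound carries 6-hydroxypyridin-3-yl, so direct evidence for this group is missing, and the range is kept wide. No step beyond the scatter is expected, in either direction, and the expected step is a 1.0-fold higher number from compound 3 to compound 4 (0.02 log units; within the scatter). For compound 4 the estimated value is 105000 nM, with an expected range from 45000 nM to 250000 nM.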

Compound 4, half-maximal cytotoxic concentration: 98500 nM
The estimate for compound 4 lay 1.1-fold (0.03 log units) above the measured number; the measured number falls inside the stated range.
By their numbers in this assay, from the lowest: compound 2; then compounds 1, 4 and 3 (each within the scatter of the next).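

In this assay, 6-hydroxypyridin-3-yl stands level with 2-chloropyridin-3-yl (a 1.0-fold lower number from compound 3 to compound 4 (0.01 log units; within the scatter)) and with 4-methoxyphenyl (a 1.2-fold higher number from compound 1 to compound 4 (0.09 log units; within the scatter)), so a third group now joins this level at the saturated chain carbon bound to a nitrogen on an aromatic ring, and the change from 0 to 1 hydrogen-bond donor in the pyridine swap leaves no step beyond the scatter. Among the compounds shown here, compound 2 remains the only compound that goes against this level, and its gap to the new group (a 7.4-fold higher number from compound 2 to compound 4 (0.87 log units; beyond the scatter)) is modest and about as large as its gaps to the other two, which sets 3,5-dichlorophenyl apart from three differing aromatic groups rather than from a single comparison. No measurement on hand explains why these three groups stand level or why 3,5-dichlorophenyl differs.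

Still open, from the compounds shown here alone, is whether a phenyl ring with a single chlorine, such as 3-chlorophenyl, would sit with compound 2 or with the other three. Also open, going by these compounds, is whether a saturated ring such as cyclohexyl, or a ring carrying a carboxylic acid or an amine, would hold this level at the same place.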